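This account rests on a few compounds, and the source may have more. Where it says the series, first, only, none or still open, it means among the compounds named here.

In an ADME assay for permeability, using PAMPA, with a stated time of 4 h, at pH 7.4 (a lower number here means that the compound crosses the layer more slowly, a higher number that the compound crosses the layer faster), compound 2 `CN(C)[C@@H]1CCN(c2cccc3c2C[C@H](CN(C)[C@H]2CCCc4cccnc42)NC3)C1` gives 14 nm/s, within the scatter of compound 1 `CN(C)[C@H]1CCN(c2cccc3c2C[C@H](CN(C)[C@H]2CCCc4cccnc42)NC3)C1` at 16 nm/s. Only these two measurements are available so far, so compound 2 has just one neighbour to be placed against.

Compound 3 `CN(C)C1CCN(c2cccc3c2C[C@H](CN(C)[C@H]2CCCc4cccnc42)NC3)CC1` carries 4-(dimethylamino)piperidin-1-yl in place of 3-(dimethylamino)pyrrolidin-1-yl on an aromatic carbon.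

Among the measured compounds shown here, the one measured step, a 1.1-fold lower number from compound 1 to compound 2 (0.06 log units; within the scatter), stays within the scatter, but its scope is limited to the fact that compounds 1 and 2 differ only in the configuration as drawn. For the measured compounds named here, it therefore offers only indirect guidance, and no measured step covers this exchange of rings. On that thin basis, no step beyond the scatter is expected in this assay, in either direction, though the range is kept wide. The expected value for compound 3 is 15 nm/s, with an estimated range of 6 nm/s to 36 nm/s. The estimated step is a 1.1-fold higher number from compound 2 to compound 3 (0.03 log units; within the scatter).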

Compound 3, apparent permeability: 44 nm/s
The estimate for compound 3 lay 2.9-fold (0.47 log units) below the measured number; measured number outside the range, above it.
By their numbers in this assay, from the lowest: compounds 2 and 1 (each within the scatter of the next); then compound 3.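

This position on an aromatic carbon now shows a response beyond the scatter in this assay: 4-(dimethylamino)piperidin-1-yl in place of 3-(dimethylamino)pyrrolidin-1-yl gives a 3.1-fold higher number from compound 2 to compound 3 (0.50 log units; beyond the scatter) and a 2.8-fold higher number from compound 1 to compound 3 (0.44 log units; beyond the scatter). The earlier pair showed only a 1.1-fold lower number from compound 1 to compound 2 (0.06 log units; within the scatter), so the exchange of rings registers here where the drawn configuration at the saturated ring carbon did not. Both steps lie beyond the scatter whichever pyrrolidine is the starting point, and the pair of starting compounds isolates stereochemistry alone: the fact that compounds 1 and 2 differ only in the configuration as drawn.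

The exchange alters ring size and the place of the dimethylamino group on the ring together, and the compounds shown do not separate the two. Also open, as far as these compounds go, is how a 3-(dimethylamino)piperidin-1-yl group or a morpholin-4-yl group on the same aromatic carbon would read in this assay.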